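The compounds below may be only part of what the source reports. "The series", "measured", "known", "first", "only" and "open" are said of these compounds alone.

Compound 2 `CC1CCCC(C(=O)N2CCc3nc(C#Cc4ccccc4)sc3C2)C1` is one of two compounds with a result in an assay on HEK293 cells for negative allosteric modulation of metabotropic glutamate receptor 5 (Homo sapiens), read by FLIPR, with a stated time of 1 h; a lower number here means a stronger inhibitor, a higher number a weaker inhibitor. In this assay compound 2 gives > 10000 nM, which is a limit of the assay and not a number. Its closest measured neighbour is compound 1 `COC1CC(C(=O)N2CCc3nc(C#Cc4ccccc4)sc3C2)C1`. In this assay compound 1 gives > 10000 nM, likewise a limit rather than a number. The step that the two limits leave unreadable from compound 1 to compound 2 cannot be sized, since both of its ends sit at the limit of > 10000 nM in this assay, at which 2 of the 2 values shown sit. Compound 3 `O=C(CC1CCOCC1)N1CCc2nc(C#Cc3ccccc3)sc2C1` differs from compound 2 in one place: (oxan-4-yl)methyl in place of 3-methylcyclohexyl on a carbonyl carbon. Going by the values given here, the only measured step, a step that the two limits leave unreadable from compound 1 to compound 2, bears on this change in kind but gives no readable size. With both measured compounds at the limit, compound 3 is expected to remain at or near it, an expected step that the limit leaves unreadable from compound 2 to compound 3 that is not distinguishable from none beyond the scatter. Compound 3 is therefore estimated at 15000 nM, expected to fall between 5000 nM and 50000 nM.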

Compound 3, half-maximal inhibitory concentration: > 10000 nM
Compound 3 ended at the assay's limit (the forecaster's own chance of this, stated with the estimate: 80%); the middle value does not contradict the limit.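

No step among compound 1, compound 2 and compound 3 can be read, because all three values are a limit of the assay and not a number: the limit of > 10000 nM in this assay, at which 3 of the 3 values shown sit.

The compounds shown leave open how far these three differ in this assay, and which group on the carbonyl carbon, if any, would give a readable value.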